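A few compounds are considered here, and "the series" means these few. Any claim that something is new, unique, unknown or untested is made for them only; others in the source may bear on it.

Measured in a physicochemical assay for lipophilicity, using the shake flask method, in phosphate buffer, measured as octanol-water partition, with a stated time of 30 min, at pH 7.4; a higher number here means a more lipophilic compound, a lower number a more polar compound:
- compound 1 `O=C(Nc1ccccc1)c1cnc(NCc2c(F)ccc3c2CCO3)n2cnnc12`: 4.1
- compound 2 `C[C@@H]1CC(=O)N(c2cnc(NCc3c(F)ccc4c3CCO4)n3cnnc23)C1`: 1.8
- compound 3 `CC1(C)CC(=O)N(c2cnc(NCc3c(F)ccc4c3CCO4)n3cnnc23)C1`: 2

Compound 3 stands with compound 2 at the low end of these three numbers, the gap between them being a number 0.20 log units higher from compound 2 to compound 3 (within the scatter). Compound 1 lies far from both.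

The next compound is compound 4 `CN(c1ccccc1)c1cnc(NCc2c(F)ccc3c2CCO3)n2cnnc12`, which has methyl(phenyl)amino in place of 4,4-dimethyl-2-oxopyrrolidin-1-yl on an aromatic carbon. Going by the values given here, no measured step makes this exact change. Among the compounds with values here, the nearest evidence is the pair of steps that replace phenylcarbamoyl, the only group here with a six-membered aromatic ring of carbon only at that place. These are a number 2.30 log units lower from compound 1 to compound 2 (beyond the scatter) and a number 2.10 log units lower from compound 1 to compound 3 (beyond the scatter), both large. Read in reverse, the second suggests a large rise for compound 4, though perhaps not the full distance, since methyl(phenyl)amino is not phenylcarbamoyl.

In this assay the expected change is a number 1.60 log units higher from compound 3 to compound 4 (beyond the scatter). The estimate for compound 4 is 3.6, with an expected range from 3 to 4.2.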

Compound 4, distribution coefficient: 3.6
Compound 4: middle estimate and measured number agree at the digits printed, and the stated range covers the measured number.
By their numbers in this assay, from the lowest: compounds 2 and 3 (each within the scatter of the next); then compound 4; then compound 1.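

In this assay, methyl(phenyl)amino and 4,4-dimethyl-2-oxopyrrolidin-1-yl have equal counts of heavy atoms and hydrogen-bond acceptors at this aromatic carbon, yet the number moves a number 1.60 log units higher from compound 3 to compound 4 (beyond the scatter) and, against the 4-methyl analogue, a number 1.80 log units higher from compound 2 to compound 4 (beyond the scatter) in the same direction. Among these four compounds, both groups carrying a six-membered aromatic ring of carbon only stand high and both 2-oxopyrrolidin-1-yl groups low, with no compound against this, but that ring does not settle the number alone, as the change is a number 0.50 log units lower from compound 1 to compound 4 (beyond the scatter) when the linking atoms differ. No measurement shown here accounts for these differences.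

From the compounds shown here alone, whether phenylamino, without the methyl, or a pyridin-3-yl ring on the same nitrogen would stay close to compound 4 remains open. So does what a morpholine at this carbon would give.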